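This account rests on a few compounds, and the source may have more. Where it says the series, first, only, none or still open, it means among the compounds named here.

Within the data shown here, in a functional assay on BJAB cells (Homo sapiens) for cytotoxicity, read by luminescence and CellTiter-Glo, with a stated time of 72 h (on this read-out higher numbers stand for an effect only at larger amounts of compound and lower numbers for an effect already at smaller amounts), compound 3 (`CCCCc1ccc(-c2ccc(-c3cc(C(=O)O)c4cc([N+](=O)[O-])ccc4n3)o2)cc1`) gives 463 nM, the lower of the two numbers available so far. Compound 1 (`CCCCc1ccc(-c2ccc(-c3cc(C(=O)O)c4cc(Br)ccc4n3)o2)cc1`) gives 2130 nM, and compound 2 (`CCCCc1ccc(-c2ccc(-c3cc(C(=O)O)c4cc(NC(C)=O)ccc4n3)o2)cc1`) is reported as "not active" (no number reported), without a number. Compound 4 (`CCCCc1ccc(-c2ccc(-c3cc(C(=O)OCC)c4cc([N+](=O)[O-])ccc4n3)o2)cc1`) keeps the nitro group of compound 3 but turns its carboxy into ethoxycarbonyl: ethyl in place of hydrogen on an oxygen next to a carbonyl group. Among the measured compounds shown here, the only measured step, a 4.6-fold lower number from compound 1 to compound 3 (0.66 log units; beyond the scatter), places nitro in place of bromo on an aromatic carbon, so no measurement tests the new change directly. That modest step offers only a rough scale. A move towards a higher number is expected, though this is a judgement with little data behind it. The estimated step is a 4.3-fold higher number from compound 3 to compound 4 (0.64 log units; beyond the scatter). Compound 4 is expected at 2000 nM, within an estimated range of 500 nM to 10000 nM.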

Compound 4, half-maximal effective concentration: > 10000 nM
Compound 4 was reported as a limit; the forecaster's own chance of this, stated with the estimate: 35%; middle value at least 5.0-fold (0.69 log units) from the limit.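

Ethyl in place of hydrogen on an oxygen next to a carbonyl group gives an at least 21-fold higher number from compound 3 to compound 4 (1.33 log units; beyond the scatter). Among these compounds, the earlier compounds changed only the group on an aromatic carbon, so this is the first sign that the carboxy group also matters, with a large step at this oxygen. Compound 4 stands at a limit of the assay, not at a number: the limit of > 10000 nM in this assay, at which 1 of the 4 values shown sits.

Whether any group on this oxygen has the same effect stays open, since methyl is absent from the compounds shown. An amide in place of the carboxy group is also absent, as is ethoxycarbonyl with bromo in place of nitro.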